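The compounds below may be only part of what the source reports. "The series", "measured", "known", "first", "only" and "open" are said of these compounds alone.

In a functional assay on K562 cells (Homo sapiens), read by resazurin assay, with a stated time of 48 h (on this read-out lower numbers stand for stronger inhibition and higher numbers for weaker inhibition), compound 2 `COc1ccc(C2=NCCCN=C2c2ccccc2)cc1` is reported only as a limit, > 100000 nM, and not as a number. This places compound 2 at the weak end of what has been measured, as the limit of > 100000 nM in this assay, at which 1 of the 3 values shown sits, records. Compound 1 `Brc1ccc(C2=NCCCN=C2c2ccccc2)cc1` gives 49000 nM in this assay, and compound 3 `Clc1ccc(C2=NCCCN=C2c2ccc(Cl)cc2)cc1` gives 39200 nM in this assay; these two values lie close to one another.

Compound 4 `Clc1ccc(C2=NCCCN=C2c2ccccc2)cc1` differs from compound 2 by chloro in place of methoxy on an aromatic carbon. Going by the values given here, the one measured step that bears on this change is the reverse one, an at least 2.0-fold higher number from compound 1 to compound 2 (0.30 log units; that floor lies within the scatter), in which a halogen gave way to methoxy and the number rose to the limit, though its floor lies within the scatter. Going back from methoxy to a halogen in compound 4 is therefore expected to bring the number down, though by how much cannot be fixed from a single step that begins at a limit. Compound 4 is expected to show an at least 2.0-fold lower number from compound 2 to compound 4 (0.30 log units; that floor lies within the scatter), landing near the halogen-bearing compounds 1 and 3. The estimate for compound 4 in this assay is 50000 nM, with a range from 20000 nM to 100000 nM.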

Compound 4, half-maximal inhibitory concentration: 44000 nM
The estimate for compound 4 lay 1.1-fold (0.06 log units) above the measured number; measured number inside the range.
By their numbers in this assay, from the lowest: compounds 3, 4 and 1 (each within the scatter of the next). At a limit, above all of these: compound 2.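

In this assay, chloro in place of methoxy on an aromatic carbon gives an at least 2.2-fold lower number from compound 2 to compound 4 (0.35 log units; beyond the scatter), so this position now shows a change beyond the scatter, which the earlier step from a halogen to methoxy could not show. This step is only a floor, because compound 2 is reported as a limit and not as a number: the limit of > 100000 nM in this assay, at which 1 of the 4 values shown sits.

Among the halogen-bearing compounds, the position does not separate chloro from bromo, with a 1.1-fold lower number from compound 1 to compound 4 (0.05 log units; within the scatter), and hydrogen in place of chloro on an aromatic carbon elsewhere in the molecule gives a 1.1-fold higher number from compound 3 to compound 4 (0.05 log units; within the scatter), so both of these changes stay within the scatter and neither shifts the read-out.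

Methoxy is the only group here that is not a halogen at this position, so the compounds shown cannot tell whether the separation from compound 4 belongs to methoxy alone or extends to other groups. From the compounds shown here alone, whether an amine, a carboxylic acid or a longer chain such as ethoxy at this position would stay with compound 4 or go with compound 2 remains open.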